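From 2-bromophenyl to 4-methoxyphenyl in a two-compound series

The compounds below may be only part of what the source reports. "The series", "measured", "known", "first", "only" and "open" are said of these compounds alone.

In a functional assay on HepG2 cells (Homo sapiens) for antiproliferative activity, read by MTT assay, with a stated time of 72 h (on this read-out lower numbers stand for stronger inhibition and higher numbers for weaker inhibition), compound 1 (`NC1=NC2(CCSCC2)N(OCCCOc2ccc(Br)cc2)C(N)=N1`) gives 1400 nM and compound 2 (`NC1=NC2(CCSCC2)N(OCCCOc2ccccc2Br)C(N)=N1`) gives 90 nM and so holds the lower of the two numbers. Compound 3 (`COc1ccc(OCCCON2C(N)=NC(N)=NC23CCSCC3)cc1`) departs from compound 2 in one place (4-methoxyphenyl in place of 2-bromophenyl on an oxygen on a saturated carbon), with 4-methoxyphenyl in place of 2-bromophenyl on an oxygen on a saturated carbon. Among the compounds with values here, one measured step bears on this: a 16-fold lower number from compound 1 to compound 2 (1.19 log units; beyond the scatter) is large and came with 2-bromophenyl in place of 4-bromophenyl. Within the data shown here, no measured compound carries 4-methoxyphenyl, so the only guide is that compound 3 gives up the 2-bromophenyl and bears a group numbered 4, as compound 1 with 1400 nM does. The expected change is an 11-fold higher number from compound 2 to compound 3 (1.05 log units; beyond the scatter) in this assay and thus a large one, toward higher numbers. The estimated value for compound 3 is 1000 nM within an expected range of 300 nM to 3000 nM on this reading.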

Compound 3, half-maximal inhibitory concentration: 880 nM
The estimate for compound 3 lay 1.1-fold (0.06 log units) above the measured number; the measured number falls inside the stated range.
By their numbers in this assay, from the lowest: compound 2; then compounds 3 and 1 (each within the scatter of the next).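

Compound 2 keeps the lowest number in this assay, and the 4-methoxyphenyl group does not carry that standing over, with a 9.8-fold higher number from compound 2 to compound 3 (0.99 log units; beyond the scatter). The two compounds with a group numbered 4 cannot be told apart, since methoxy in place of bromo on the aromatic carbon gives a 1.6-fold lower number from compound 1 to compound 3 (0.20 log units; within the scatter), so the lower number of compound 2 now stands apart from two different groups numbered 4 rather than one. Nothing available accounts for these differences.

The compounds shown leave open whether the lower number of compound 2 belongs to the bromo itself or would also hold with methoxy in its place. They also leave open how an unsubstituted phenyl, or an amine on the aromatic carbon, would compare.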